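This account rests on a few compounds, and the source may have more. Where it says the series, first, only, none or still open, it means among the compounds named here.

Series notes, step from compound 1 to compound 4.

For the measured compounds named here, compound 1 `CCCC(Oc1ccc(-n2cc(C(=O)N(C)C)cn2)cc1)c1ccc(C(=O)NCCC(=O)O)cc1` is the weakest of the three compounds measured so far in an assay on cells for displacement of a labelled ligand from Glucagon receptor (Homo sapiens), in the presence of a further agent that is not named here; on this read-out lower numbers stand for stronger inhibition and higher numbers for weaker inhibition: compound 1 gives 6500 nM, and its distance to both other compounds lies beyond the usual scatter. Compound 2 `CCCC(Oc1cnc(-n2cc(C(F)(F)F)cn2)nc1)c1ccc(C(=O)NCCC(=O)O)cc1`, which joins a trifluoromethyl-bearing pyrazole to a different six-membered core, gives in this assay a value of 1100 nM. Compound 3 `CC(C)(C)C(Oc1ccc(-n2cc(C(F)(F)F)cn2)cc1)c1ccc(C(=O)NCCC(=O)O)cc1`, with a tert-butyl group in place of the propyl chain and again a trifluoromethyl-bearing pyrazole, gives in this assay a value of 170 nM, the lowest number of the three.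

Compound 4 `CCCC(Oc1ccc(-n2cc(C(F)(F)F)c(C)n2)cc1)c1ccc(C(=O)NCCC(=O)O)cc1` has not yet been measured. It keeps the propyl chain and the carbon-only core of compound 1 and differs in one place: 3-methyl-4-(trifluoromethyl)-1H-pyrazol-1-yl in place of 4-(dimethylcarbamoyl)-1H-pyrazol-1-yl on an aromatic carbon. Going by the values given here, no measured pair reproduces this exact change, so the step has to be judged from the whole set. Both compounds carrying a trifluoromethyl-bearing pyrazole sit well under compound 1, so a drop in the number is expected, though the methyl addition and the unchanged propyl chain leave the size uncertain. The step from compound 1 to compound 4 in this assay is estimated at a 9.3-fold lower number from compound 1 to compound 4 (0.97 log units; beyond the scatter). For compound 4 the expected value in this assay is 700 nM, with a likely range from 200 nM to 2500 nM.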

Compound 4, inhibition constant: 1100 nM
Compound 4: middle estimate off by 1.6-fold (0.20 log units), on the low side; measured number inside the range.
By their numbers in this assay, from the lowest: compound 3; then compounds 2 and 4 (each within the scatter of the next); then compound 1.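

In this assay, the substituent at this position, on an aromatic carbon para to a large group, moves the number by itself: with the propyl chain and the shared core held fixed, 3-methyl-4-(trifluoromethyl)-1H-pyrazol-1-yl in place of 4-(dimethylcarbamoyl)-1H-pyrazol-1-yl gives a 5.9-fold lower number from compound 1 to compound 4 (0.77 log units; beyond the scatter). For the compounds shown here, this is the first single-place change, as the earlier compounds differ from one another in more than one place. The change removes the dimethylcarbamoyl group and adds both trifluoromethyl and methyl, so this one step cannot be divided among those groups, and no supporting data offer an explanation for it.

The compounds shown leave open how much of the step belongs to the trifluoromethyl group and how much to the methyl group on the pyrazole. Going by these compounds, it also remains open whether a nitrile or a chlorine on the pyrazole, or a longer chain in place of the propyl chain, would keep the number at this level.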